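The compounds below may be only part of what the source reports. "The series", "measured", "known", "first", "only" and "open" are said of these compounds alone.

The measured compounds are compound 1 `CNc1nc(-c2ccccc2)nc2c1nnn2Cc1ccccc1` at 353 nM, compound 2 `CNc1nc(-c2ccccc2)nc2c1nnn2Cc1ccccc1F` at 25 nM and compound 3 `CCCCNc1nc(-c2ccccc2)nc2c1nnn2Cc1ccccc1` at 11 nM, all in an assay on Cerebral cortex for displacement of a labelled ligand from adenosine receptor A1 (Bos taurus); a higher number here means a weaker inhibitor, a lower number a stronger inhibitor.

Compound 4 `CCCCNc1nc(-c2ccccc2)nc2c1nnn2Cc1ccccc1F` has not yet been measured. It differs from compound 3 by fluoro in place of hydrogen on an aromatic carbon. The same change, (fluoro in place of hydrogen on an aromatic carbon), has been made once before among these compounds and gave a 14-fold lower number from compound 1 to compound 2 (1.15 log units; beyond the scatter). The two cores on which it is made differ by propyl in place of hydrogen on a saturated chain carbon bound to a nitrogen on an aromatic ring, the change that gave a 32-fold lower number from compound 1 to compound 3 (1.51 log units; beyond the scatter) and left compound 3 with the lowest number of the three. Because compound 3 already stands at 11 nM, the step is expected to be smaller than the earlier one, and the expected step is a 5.5-fold lower number from compound 3 to compound 4 (0.74 log units; beyond the scatter). Compound 4 is expected to give about 2 nM in this assay, between 0.6 nM and 6 nM.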

Compound 4, inhibition constant: 4.3 nM
Beside the measured number, compound 4's estimate is 2.2-fold (0.33 log units) below it; the measured number falls inside the stated range.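

In this assay, fluoro in place of hydrogen keeps its direction on the core of compound 3, giving a 2.6-fold lower number from compound 3 to compound 4 (0.41 log units; beyond the scatter), but it does not keep its size: the same change on two cores in this assay, a 14-fold lower number (1.15 log units; beyond the scatter) from compound 1 to compound 2 and a 2.6-fold lower number (0.41 log units; beyond the scatter) from compound 3 to compound 4, 5.5-fold (0.74 log units) apart, beyond the scatter of two such steps

The propyl change also keeps its direction, giving a 5.8-fold lower number from compound 2 to compound 4 (0.76 log units; beyond the scatter), and it too is smaller on the fluorinated core: the same change on two cores in this assay, a 32-fold lower number (1.51 log units; beyond the scatter) from compound 1 to compound 3 and a 5.8-fold lower number (0.76 log units; beyond the scatter) from compound 2 to compound 4, 5.5-fold (0.74 log units) apart, beyond the scatter of two such steps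

So in these four compounds, each change lowers the number on both cores but neither step carries over at its earlier size, and this one set of four does not show why, or whether the same holds on other cores.

Going by these compounds, it remains open whether a chlorine or a methoxy group in place of the fluoro would follow the same course. For the compounds shown here, the same is true of a longer chain than the one in compound 3.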